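A Methyl Added Beside the Furan Group

The compounds below may be only part of what the source reports. "The series", "measured", "known", "first", "only" and "open" are said of these compounds alone.

Three compounds have been measured in a functional assay on Right cardiac atrium for agonist activity at histamine H2 receptor (Cavia porcellus), with a stated time of 30 min, in the presence of a further agent that is not named here; a higher number here means that more compound is needed for the effect, a lower number that less compound is needed:

Compound 1, `Cc1nc(N)sc1CCCN/C(N)=N/C(=O)NC(C)c1cccc(F)c1`, gives 26.3 nM.
Compound 2, `CCCCCCNC(=O)/N=C(\N)NCCCc1sc(N)nc1C`, gives 15.9 nM.
Compound 3, `Cc1nc(N)sc1CCCN/C(N)=N/C(=O)NCc1ccco1`, gives 11.8 nM.

Compound 3 has the lowest number of the three. Its gap to compound 2 is within the scatter, so the two cannot be ordered; its gap to compound 1 is beyond the scatter. For the measured compounds named here, the one step between measured compounds, a 1.3-fold lower number from compound 2 to compound 3 (0.13 log units; within the scatter), is within the scatter and concerns the group on the chain carbon, not a change on that carbon itself.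

Compound 4, `Cc1nc(N)sc1CCCN/C(N)=N/C(=O)NC(C)c1ccco1`, is the next compound. Compared with compound 3 the change is methyl in place of hydrogen on a saturated chain carbon bound to an amide-type nitrogen and an aromatic carbon. Going by the values given here, no measured step covers this exact change. Among the compounds with values here, compound 1 also carries a methyl on a saturated chain carbon bound to an amide-type nitrogen and an aromatic carbon, but its aromatic ring differs from the one in compound 3, so only the two values can be compared: compound 1 sits higher than compound 3 by a margin beyond the scatter. On that thin basis, a modest rise in this assay is expected, and the estimated step is a 1.5-fold higher number from compound 3 to compound 4 (0.18 log units; within the scatter), which may well fall within the scatter.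

Compound 4 is therefore estimated at 18 nM, with a range from 8 nM to 45 nM.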

Compound 4, half-maximal effective concentration: 9.77 nM
Estimate against measurement, compound 4: 1.8-fold (0.27 log units) above, within the range that was stated.
By their numbers in this assay, from the lowest: compounds 4, 3, 2 and 1 (each within the scatter of the next, the first and the last beyond it).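

For the compounds shown here, the first direct reading of this change in this assay is a 1.2-fold lower number from compound 3 to compound 4 (0.08 log units; within the scatter) and so the added methyl leaves compound 4 indistinguishable from compound 3, which has only hydrogen on that carbon. Going by these compounds alone, with a methyl on this carbon in both compounds, the ring can now be compared on its own: furan-2-yl in place of 3-fluorophenyl gives a 2.7-fold lower number from compound 1 to compound 4 (0.43 log units; beyond the scatter) and this is the only new step that clears the scatter, so the higher number of compound 1 goes with its 3-fluorophenyl group and not with the methyl. The swap of hexyl for 1-(furan-2-yl)ethyl on an amide-type nitrogen gives a 1.6-fold lower number from compound 2 to compound 4 (0.21 log units; within the scatter) and therefore leaves those two compounds unordered, just as compound 2 and compound 3 were.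

As far as these compounds go, what an ethyl, a cyclopropyl or an amine on that same chain carbon would do stays open, as does the effect of the methyl on groups other than furan-2-yl and 3-fluorophenyl. Nothing in the data on hand gives a reason for these numbers.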